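The compounds below may be only part of what the source reports. "The series", "measured", "known", "first", "only" and "open" are said of these compounds alone.

Measured compounds:
- compound 1 `O=C(c1cc(Cc2n[nH]c(=O)c3ccccc23)ccc1F)N1CCc2nc(Cl)ncc2C1` — "nd" (no result reported)
- compound 2 `O=C(c1cc(Cc2n[nH]c(=O)c3ccccc23)ccc1F)N1CCc2nc(N3CCCC3)ncc2C1` — 7810 nM
- compound 3 `CCN(CC)c1ncc2c(n1)CCN(C(=O)c1cc(Cc3n[nH]c(=O)c4ccccc34)ccc1F)C2` — 66800 nM

In a functional assay on HCC1937 cells (Homo sapiens) for inhibition, read by MTT assay, with a stated time of 48 h (on this read-out higher numbers stand for weaker inhibition and lower numbers for stronger inhibition), compound 2 gives 7810 nM, the lower of the two numbers reported, while compound 3 gives 66800 nM. For compound 1 no result was reported in this assay. Among the measured compounds shown here, the single step among the measured compounds is an 8.6-fold higher number from compound 2 to compound 3 (0.93 log units; beyond the scatter), in which a cyclic amine gave way to an acyclic one and inhibition became weaker.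

Compound 4 `CCCCN(CCCC)c1ncc2c(n1)CCN(C(=O)c1cc(Cc3n[nH]c(=O)c4ccccc34)ccc1F)C2` differs from compound 2 by dibutylamino in place of pyrrolidin-1-yl on an aromatic carbon. This change resembles the step from compound 2 to compound 3 in that the cyclic amine is again replaced by an acyclic dialkylamine, now carrying longer chains. For the measured compounds named here, the one relevant step points toward weaker inhibition in this assay, and no measured compound shows what the longer chains add on their own. Compound 4 is therefore expected to show a 6.4-fold higher number from compound 2 to compound 4 (0.81 log units; beyond the scatter), with an estimated value of about 50000 nM and a likely range from 15000 nM to 200000 nM.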

Compound 4, half-maximal inhibitory concentration: > 200000 nM
Compound 4 gave a limit, no number; the forecaster's own chance of this, stated with the estimate: 25%; middle value at least 4.0-fold (0.60 log units) from the limit.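

In this assay compound 4 gives a limit and not a number: the limit of > 200000 nM in this assay, at which 1 of the 4 values shown sits. Even so, both steps can be read in one direction: replacing the pyrrolidin-1-yl ring with open dibutylamino chains gives an at least 25-fold higher number from compound 2 to compound 4 (1.40 log units; beyond the scatter) and lengthening diethylamino to dibutylamino gives an at least 2.9-fold higher number from compound 3 to compound 4 (0.47 log units; beyond the scatter). At this aromatic carbon between two ring nitrogen atoms, chain length therefore matters in its own right, which the earlier pair could not show, and inhibition weakens in the order pyrrolidin-1-yl, diethylamino, dibutylamino.

From the compounds shown here alone, how far compound 4 lies beyond its limit remains unknown, so the full size of both steps is open. Also open, going by these compounds, is whether a smaller open amine such as dimethylamino, or another ring such as morpholine, would match or improve on the pyrrolidin-1-yl of compound 2.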